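Dropping one fluorine from compound 3: an expectation

The source may hold more compounds than are shown below. What is called first, only, known or untested is meant among the compounds shown, and "the series" means these compounds.

Compounds measured so far:
compound 1 `Cn1cc(-c2ccc(NC(=O)c3cn(CC4CCOCC4)cc(-c4ccc(F)cc4F)c3=O)cc2)c2c(N)ncnc21`, 0.8 nM
compound 2 `Cn1cc(-c2ccc(NC(=O)c3cn(CC4CCOCC4)cc(-c4ccc(F)cc4)c3=O)c(F)c2)c2c(N)ncnc21`, 0.2 nM
compound 3 `Cn1cc(-c2cc(F)c(NC(=O)c3cn(CC4CCOCC4)cc(-c4ccc(F)cc4)c3=O)cc2F)c2c(N)ncnc21`, 0.5 nM

In an assay on isolated protein for inhibition of tyrosine-protein kinase receptor UFO (Homo sapiens), read by ELISA (on this read-out higher numbers stand for weaker inhibition and lower numbers for stronger inhibition), compound 3 gives the second highest of the three numbers; compound 1 lies within the scatter of it, while compound 2 sits lower, beyond the scatter. Compound 4 `Cn1cc(-c2ccc(NC(=O)c3cn(CC4CCOCC4)cc(-c4ccc(F)cc4)c3=O)cc2F)c2c(N)ncnc21` differs from compound 3 by hydrogen in place of fluoro on an aromatic carbon. Within the data shown here, the only single-point step on record, a 2.5-fold higher number from compound 2 to compound 3 (0.40 log units; beyond the scatter), concerns the other fluoro on that ring, so it bears on this change only indirectly; the fluoro removed here has no measured counterpart. Compound 4 is therefore expected to stay close to compound 3, with a 1.4-fold higher number from compound 3 to compound 4 (0.15 log units; within the scatter), its number estimated at 0.7 nM (range 0.3 nM to 1.8 nM).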

Compound 4, half-maximal inhibitory concentration: 0.8 nM
Compound 4: middle estimate off by 1.1-fold (0.06 log units), on the low side; the measured number falls inside the stated range.
By their numbers in this assay, from the lowest: compound 2; then compounds 3, 1 and 4 (each within the scatter of the next).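

In this assay the change gives a 1.6-fold higher number from compound 3 to compound 4 (0.20 log units; within the scatter) and so stays within the scatter. At this aromatic carbon, ortho to a large group and para to a fluoro group, hydrogen and fluoro are therefore not told apart by this read-out, whereas the step at the other fluoro on that ring, a 2.5-fold higher number from compound 2 to compound 3 (0.40 log units; beyond the scatter), lies beyond the scatter. Nothing on record gives a reason for this result. Going by these compounds, whether chloro, methoxy or an amine on this carbon would stay as close to fluoro and hydrogen remains open.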